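A few compounds are considered here, and "the series" means these few. Any claim that something is new, unique, unknown or untested is made for them only; others in the source may bear on it.

In a functional assay for inhibition, with Homo sapiens as the target (a higher number here means a weaker inhibitor, a lower number a stronger inhibitor), compound 1 `OCc1cc(-c2ccccc2)c2ccc(OCc3cccc(C4(O)CCOCC4)c3)cc2c1` gives 9 nM and compound 2 `CC(O)c1cc(-c2ccccc2)c2ccc(OCc3cccc(C4(O)CCOCC4)c3)cc2c1` gives 28 nM as the higher of the two numbers, which makes compound 2 the weaker inhibitor of the pair. Compound 3 `CC(C)(O)c1cc(-c2ccccc2)c2ccc(OCc3cccc(C4(O)CCOCC4)c3)cc2c1` is still unmeasured. The change leading to it is counted as methyl in place of hydrogen on a saturated chain carbon bound to an aromatic carbon, an oxygen on a saturated carbon and a saturated chain carbon and amounts to methyl in place of hydrogen on a saturated chain carbon bound to an aromatic carbon, an oxygen on a saturated carbon and a saturated chain carbon, so that 1-hydroxyethyl becomes 1-hydroxy-1-methylethyl. Within the data shown here, only one measured step bears on this, the same exchange of hydrogen for methyl on that chain carbon. That step is a 3.1-fold higher number from compound 1 to compound 2 (0.49 log units; beyond the scatter) and it points to a further rise of similar or somewhat smaller size for compound 3, although a single step is thin ground for such an expectation. The estimated step is a 2.1-fold higher number from compound 2 to compound 3 (0.33 log units; beyond the scatter) toward a weaker inhibitor. In this assay the expected value for compound 3 is 60 nM with an estimated range from 18 nM to 200 nM for repeated measurements.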

Compound 3, half-maximal inhibitory concentration: 59 nM
Compound 3: middle estimate off by 1.0-fold (0.01 log units), on the high side, within the range that was stated.
By their numbers in this assay, from the lowest: compound 1; then compound 2; then compound 3.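

In this assay, the second methyl on the saturated chain carbon moves the number in the same direction as the first, giving a 2.1-fold higher number from compound 2 to compound 3 (0.32 log units; beyond the scatter), so each added methyl across these three compounds goes with a weaker inhibitor, and none of them goes against that order. Over the whole change, 1-hydroxy-1-methylethyl in place of hydroxymethyl on an aromatic carbon gives a 6.6-fold higher number from compound 1 to compound 3 (0.82 log units; beyond the scatter), which shows that the two methyl steps add up to a larger loss than either one alone and leaves the hydroxymethyl of compound 1 as the strongest inhibitor of the three. Nothing available explains why the number rises along this series.

All three compounds keep the hydroxyl on this chain carbon and differ only in methyl against hydrogen, so the series cannot tell how much that hydroxyl itself matters. As far as these compounds go, it remains open how an amine, a carboxylic acid or a methyl ether at this place would read in this assay, and whether a longer chain such as 1-hydroxypropyl would follow the same trend as the methyl steps.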